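Methoxy for phenyl on the piperidine of compound 3

The source may report more compounds than this note shows. Statements on the series, on what has been measured and on what is new or still open speak of the compounds shown alone.

Three compounds share one core and differ only in the group attached at a single place on it. Compound 1 `CC(C(=O)NCc1ccc(C(F)(F)F)nc1Nc1ccc(F)cc1)c1ccc(NS(C)(=O)=O)c(F)c1` gives 39.2 nM in a functional assay on CHO-K1 cells for antagonist activity at transient receptor potential cation channel subfamily V member 1 (Homo sapiens), read by FLIPR; a higher number here means a weaker inhibitor, a lower number a stronger inhibitor. Compound 2 `CC(C(=O)NCc1ccc(C(F)(F)F)nc1NCc1ccccc1)c1ccc(NS(C)(=O)=O)c(F)c1` gives 15.8 nM in this assay. Compound 3 `CC(C(=O)NCc1ccc(C(F)(F)F)nc1N1CCC(c2ccccc2)CC1)c1ccc(NS(C)(=O)=O)c(F)c1` gives 0.6 nM in this assay, the lowest of the three numbers: the steps of a 65-fold lower number from compound 1 to compound 3 (1.82 log units; beyond the scatter) and a 26-fold lower number from compound 2 to compound 3 (1.42 log units; beyond the scatter) are both large, while a 2.5-fold lower number from compound 1 to compound 2 (0.39 log units; beyond the scatter) is modest. Compound 4 `COC1CCN(c2nc(C(F)(F)F)ccc2CNC(=O)C(C)c2ccc(NS(C)(=O)=O)c(F)c2)CC1` has not been measured; the change is methoxy in place of phenyl on a saturated ring carbon. For the measured compounds named here, no measured step alters a substituent on the piperidine ring, so none bears directly on this change. The two steps into compound 3 show that bringing in 4-phenylpiperidin-1-yl gave the large gain, and compound 4 keeps the piperidine but drops its phenyl, so part of that gain is expected to be lost. The expected step is a 17-fold higher number from compound 3 to compound 4 (1.22 log units; beyond the scatter), toward a higher number. Compound 4 is estimated at 10 nM, with a range of 2 nM to 60 nM.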

Compound 4, inhibition constant: 2.4 nM
Compound 4: the middle estimate sits 4.2-fold (0.62 log units) above what was measured; the measured number falls inside the stated range.
By their numbers in this assay, from the lowest: compound 3; then compound 4; then compound 2; then compound 1.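

In this assay, most of the gain from the 4-phenylpiperidin-1-yl group survives without its phenyl: a 4.0-fold higher number from compound 3 to compound 4 (0.60 log units; beyond the scatter) is only a modest loss, even though methoxy has no ring and fewer heavy atoms. The 4-methoxypiperidin-1-yl group still improves on both amino groups, giving a 6.6-fold lower number from compound 2 to compound 4 (0.82 log units; beyond the scatter) when it replaces benzylamino and a 16-fold lower number from compound 1 to compound 4 (1.21 log units; beyond the scatter) when it replaces (4-fluorophenyl)amino, so at this aromatic carbon the advantage of the piperidines over these two groups does not require the phenyl. No measurement available here explains these differences.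

Still open, as far as these compounds go, is how much of the remaining activity depends on the methoxy oxygen rather than on the piperidine itself. An unsubstituted piperidin-1-yl, or a methyl, hydroxyl or amine on the same saturated ring carbon, would separate these contributions.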